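The source may report more compounds than this note shows. Statements on the series, on what has been measured and on what is new or still open speak of the compounds shown alone.

Compound 1 `Nc1ccccc1NC(=O)c1ccc(CSc2cccc(F)c2)cc1` 18.6%
Compound 2 `Nc1ccccc1NC(=O)c1ccc(CSc2ccc(Br)cc2)cc1` 10%
Compound 3 `Nc1ccccc1NC(=O)/C=C/c1ccc(CSc2cccc3ccccc23)cc1` 3.7%

All three values come from a functional assay on SMMC-7721 cells (Homo sapiens) for inhibition, read by CCK-8 assay, with a stated time of 72 h, tested at 2 uM (on this read-out lower numbers stand for less inhibition of growth and higher numbers for more inhibition of growth at the one concentration tested), and compound 2 at 10% lies within the scatter of both other compounds. Compound 4 `Nc1ccccc1NC(=O)c1ccc(CSc2ccc(F)cc2)cc1` carries fluoro in place of bromo on an aromatic carbon, para to a large group (fluoro in place of bromo on an aromatic carbon). Within the data shown here, the one measured step that bears on this is a number 8.6 percentage points lower from compound 1 to compound 2 (within the scatter) and it also exchanges these two halogens on the ring attached to sulfur, though at different positions. No step beyond the scatter is therefore expected, in either direction. The estimated step is a number 4 percentage points higher from compound 2 to compound 4 (within the scatter) and it stays small. The estimate for compound 4 is 14% with an expected range from 3% to 28% in this read-out.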

Compound 4, percent growth inhibition at one concentration: 6.58%
Beside the measured number, compound 4's estimate is 7.4 percentage points above it, within the range that was stated.
By their numbers in this assay, from the lowest: compounds 3, 4, 2 and 1 (each within the scatter of the next, the first and the last beyond it).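

In this assay the exchange of halogen on the aromatic carbon para to a large group reads as a number 3.4 percentage points lower from compound 2 to compound 4 (within the scatter), so fluoro and bromo are not told apart at this place. With 4-fluorophenyl in place of 3-fluorophenyl on the sulfur, the reading is a number 12 percentage points lower from compound 1 to compound 4 (beyond the scatter), so the place of the fluoro gives a modest step where the kind of halogen gives none. Nothing available explains either step.

Open, on these data alone, are a methoxy, an amine or a carboxylic acid at this place. Also open, as far as these compounds go, is whether the same modest step appears between 3-bromophenyl and 4-bromophenyl on the sulfur.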